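Drawing the Stereocentre: From Compound 1 to Compound 4

This account rests on a few compounds, and the source may have more. Where it says the series, first, only, none or still open, it means among the compounds named here.

Of the compounds shown here, three have been measured in a functional assay on the whole organism (strain Wistar) for inhibition, with Rattus norvegicus as the target, read by paw edema, with a stated time of 1 h, at a dose of 10 mg/kg by the intraperitoneal route; a lower number here means less inhibition, a higher number more inhibition at the dose given (going by the name of the read-out). Compound 1 `Cc1ncc([N+](=O)[O-])n1CCOC(=O)c1cc(NC(=O)C(C)NC(=O)OCc2ccccc2)ccc1O` gives 57.9% in this assay. Compound 2 `CC(=O)Nc1ccc(O)c(C(=O)OCCn2c([N+](=O)[O-])cnc2C)c1` gives 63.4%, a number within the scatter of compound 1, so the two cannot be told apart. Compound 3 `CC(=O)Nc1ccc(O)c(C(=O)O)c1` gives 43.3%, a number that lies beyond the scatter below compound 1. Compound 1 thus stands second highest of the three numbers, with compound 2 nearest and compound 3 furthest from it.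

Compound 4 `Cc1ncc([N+](=O)[O-])n1CCOC(=O)c1cc(NC(=O)[C@H](C)NC(=O)OCc2ccccc2)ccc1O` has not yet been measured. How it differs from compound 1: the two compounds have the same atoms and bonds; at least one stereo element is drawn with a configuration in one of them and without one in the other: 1 of 1 stereo elements differ; a stereocentre at a saturated chain carbon is drawn without a configuration in compound 1 and S in compound 4. Nothing enters and nothing leaves; only one stereocentre at a saturated chain carbon is drawn as S where it had no configuration before. Within the data shown here, no measured pair shows what such a change does in this assay. With the atoms and bonds unchanged, the expected step is a number 0.1 percentage points higher from compound 1 to compound 4 (within the scatter), none beyond the scatter. Compound 4 is therefore expected to give 58%, within a range from 46% to 70%.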

Compound 4, a percentage reported as inhibition, in the whole organism at one dose (the size of the read-out at that dose, not a potency): 58.5%
For compound 4 the middle estimate is 0.5 percentage points below the measured one; low and high end bracket the measured number.
By their numbers in this assay, from the lowest: compound 3; then compounds 1, 4 and 2 (each within the scatter of the next).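

In this assay, the step is a number 0.6 percentage points higher from compound 1 to compound 4 (within the scatter). Among these compounds, this is the first measured pair that isolates a change at this stereocentre at the saturated chain carbon, and it does not separate a compound drawn as S from the same atoms and bonds drawn without a configuration. The pair can be read only as far as one fact allows: the fact that one of compounds 1 and 4 is drawn with a defined configuration and the other without, at the place where they differ

The compounds shown leave open what an R configuration at this carbon would give, since no compound here is drawn that way. They also leave open whether a longer chain in place of the methyl group on this carbon, or a free amine in place of the benzyl carbamate, would move the number beyond the scatter.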